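A Nitrobenzofurazan Ester Series: Swapping an Aryl Amide for an Amine Chain

The source may report more compounds than this note shows. Statements on the series, on what has been measured and on what is new or still open speak of the compounds shown alone.

Compound 1 `O=C(CCC(=O)OCCCCCCSc1ccc([N+](=O)[O-])c2nonc12)Nc1ccccc1Cl` was tested in a functional assay on A549 cells (Homo sapiens) for inhibition, read by MTT assay, with a stated time of 72 h (a lower number here means a stronger inhibitor, a higher number a weaker inhibitor), and gave 2750 nM. Compound 2 `O=C(CCC(=O)OCCCCCCSc1ccc([N+](=O)[O-])c2nonc12)Nc1cccc(Cl)c1` differs from it only by 3-chlorophenyl in place of 2-chlorophenyl on an amide-type nitrogen, and in this assay compound 2 gave 5290 nM; the step of a 1.9-fold higher number from compound 1 to compound 2 (0.28 log units; within the scatter) is within the scatter, so compound 1 has the lower of the two numbers without being separable from compound 2. Compound 3 `CCN(CC)CCCNC(=O)CCC(=O)OCCCCCCSc1ccc([N+](=O)[O-])c2nonc12` has not yet been measured. It differs from compound 1 by 3-(diethylamino)propyl in place of 2-chlorophenyl on an amide-type nitrogen. Among the measured compounds shown here, no measured step touches this kind of change, since the only step available moves a chlorine around an aromatic ring and stays within the scatter; the direction of the step is therefore open. Compound 3 is expected to give about 4000 nM in this assay, with a range from 1000 nM to 16000 nM. The step of a 1.5-fold higher number from compound 1 to compound 3 (0.16 log units; within the scatter) is thus estimated to be small against the wide uncertainty.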

Compound 3, half-maximal inhibitory concentration: 2570 nM
The estimate for compound 3 lay 1.6-fold (0.19 log units) above the measured number; the range from low to high includes it.
By their numbers in this assay, from the lowest: compounds 3, 1 and 2 (each within the scatter of the next, the first and the last beyond it).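

Among the compounds shown here, compound 3 shows that the amide-type nitrogen accepts a far larger change than moving a chlorine: in this assay an open chain ending in an amine, 3-(diethylamino)propyl, replaces the 2-chlorophenyl ring with no step that stands out from the scatter (a 1.1-fold lower number from compound 1 to compound 3 (0.03 log units; within the scatter)). Measured against the 3-chlorophenyl amide, the same kind of swap does pass the scatter, though only modestly (a 2.1-fold lower number from compound 2 to compound 3 (0.31 log units; beyond the scatter)), and compounds 1 and 2 lie within the scatter of each other, so this is no firm sign that the chain outperforms an aromatic ring. Nothing available here gives a reason for these numbers. A plain hexyl chain, or a propyl chain ending in a morpholine or a carboxylic acid, on the same nitrogen would test whether the terminal amine matters or the chain alone is enough. From the compounds shown here alone, whether an unsubstituted phenyl or a shorter amine chain gives a similar number also stays open.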